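Replacing an Amide Side Chain with a Methylamine

The source may hold more compounds than are shown below. What is called first, only, known or untested is meant among the compounds shown, and "the series" means these compounds.

Two measured compounds share one core. Compound 1 `C[C@H](Nc1cc(=O)oc2cc(OCc3ccccc3)ccc12)C(N)=O` carries a (1-carbamoylethyl)amino group on an aromatic carbon, and in an assay (strain Wistar) for inhibition of Amine oxidase [flavin-containing] A (Rattus norvegicus) (on this read-out lower numbers stand for stronger inhibition and higher numbers for weaker inhibition), compound 1 gives 100000 nM. Compound 2 `CC(C(N)=O)c1cc(=O)oc2cc(OCc3ccccc3)ccc12` has the 1-carbamoylethyl group joined directly to that carbon, and in this assay compound 2 gives 6260 nM. Among the compounds with values here, the difference is a 16-fold lower number from compound 1 to compound 2 (1.20 log units; beyond the scatter), which leaves compound 2 with the lower of the two numbers so far. Compound 3 `CNCc1cc(=O)oc2cc(OCc3ccccc3)ccc12` introduces a further change: (methylamino)methyl in place of 1-carbamoylethyl on an aromatic carbon. Within the data shown here, the only measured step offers little guidance, because a 16-fold lower number from compound 1 to compound 2 (1.20 log units; beyond the scatter) concerned the link to the ring rather than the side chain itself, so no step beyond the scatter is expected in either direction. Compound 3 is therefore estimated to give about 5000 nM in this assay, most likely between 800 nM and 30000 nM. That estimate corresponds to a 1.3-fold lower number from compound 2 to compound 3 (0.10 log units; within the scatter), a step expected to stay within the usual scatter.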

Compound 3, half-maximal inhibitory concentration: 15400 nM
Estimate against measurement, compound 3: 3.1-fold (0.49 log units) below; measured number inside the range.
By their numbers in this assay, from the lowest: compound 2; then compound 3; then compound 1.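

In this assay, the amide side chain can give way to the (methylamino)methyl group, which has fewer heavy atoms and no carbonyl, at only a modest cost: a 2.5-fold higher number from compound 2 to compound 3 (0.39 log units; beyond the scatter). Compound 3 still keeps much of the gain over the nitrogen-linked side chain, with a 6.5-fold lower number from compound 1 to compound 3 (0.81 log units; beyond the scatter), so among these three compounds, the two with a carbon joined directly to the ring give the lower numbers. Nothing shown explains these differences.

Compound 3 differs from compound 2 in chain length, branching and the amide at once, so the single feature that matters remains unclear. A plain aminomethyl group, a dimethylaminomethyl group or a longer chain such as 2-(methylamino)ethyl at this position could begin to pull those features apart.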